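A Heavier Halogen on the Shared Core

A few compounds are considered here, and "the series" means these few. Any claim that something is new, unique, unknown or untested is made for them only; others in the source may bear on it.

Of the compounds shown here, three built on one shared core have been measured in a functional assay on A549 cells (Homo sapiens) for cytotoxicity, read by XTT assay, with a stated time of 24 h; a higher number here means a weaker inhibitor, a lower number a stronger inhibitor. Compound 1 `Cn1nnnc1SCC(=O)N/N=C/c1ccc([N+](=O)[O-])cc1` gives 632000 nM, compound 2 `Cn1nnnc1SCC(=O)N/N=C/c1ccc(F)cc1` gives 3160000 nM, and compound 3 `Cn1nnnc1SCC(=O)N/N=C/c1ccc(Cl)cc1` gives 100000 nM. Compound 3 stands lowest and is the strongest inhibitor of the three: the step from compound 1 to compound 3 was a 6.3-fold lower number from compound 1 to compound 3 (0.80 log units; beyond the scatter), and the step from compound 2 to compound 3 was a 32-fold lower number from compound 2 to compound 3 (1.50 log units; beyond the scatter).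

Compound 4 `Cn1nnnc1SCC(=O)N/N=C/c1ccc(Br)cc1` differs from compound 3 in a single place: bromo in place of chloro on an aromatic carbon. Going by the values given here, the steps that bear on this change are the two already named, both reaching compound 3 and both lowering the number when the group on that aromatic carbon was exchanged. Among the compounds with values here, no measured step exchanges chloro for bromo, so the direction of this step is not settled by the data. Compound 4 is expected near 60000 nM, within 15000 nM to 250000 nM. The expected step from compound 3 to compound 4 is a 1.7-fold lower number from compound 3 to compound 4 (0.22 log units; within the scatter), small enough that it may fall within the scatter.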

Compound 4, half-maximal inhibitory concentration: > 10000000 nM
Compound 4: a limit, no number (the forecaster's own chance of this, stated with the estimate: 5%); middle value at least 160-fold (2.22 log units) from the limit.
By their numbers in this assay, from the lowest: compound 3; then compound 1; then compound 2. At a limit, above all of these: compound 4.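

The earlier compounds shown here showed this aromatic carbon tolerating exchanges within a measured range, with chloro lowest, so fluoro, nitro and chloro could all be given a number. Bromo changes that picture: in this assay, a single halogen exchange gives an at least 100-fold higher number from compound 3 to compound 4 (2.00 log units; beyond the scatter), and compound 4 also ends past the other two, with an at least 3.1-fold higher number from compound 2 to compound 4 (0.50 log units; beyond the scatter) and an at least 15-fold higher number from compound 1 to compound 4 (1.19 log units; beyond the scatter), so the halogens shown follow no steady order, with chloro lower than both fluoro and bromo. Compound 4 has only a limit here, not a number: the limit of > 10000000 nM in this assay, at which 1 of the 4 values shown sits.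

Going by these compounds, how far compound 4 truly lies beyond that limit stays unknown, so the full size of these steps does too. On these data alone, whether the low value is special to chloro also stays open, and an iodo, methyl or methoxy group on this aromatic carbon would bear on that.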